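From thiophen-2-yl to 3,5-dichlorophenyl on a carbonyl carbon

A few compounds are considered here, and "the series" means these few. Any claim that something is new, unique, unknown or untested is made for them only; others in the source may bear on it.

Two compounds measured so far in a functional assay on HUVEC cells (Homo sapiens) for inhibition (a higher number here means a weaker inhibitor, a lower number a stronger inhibitor), are these:
- compound 1 `COc1cc(/C=C/C(=O)c2cccc(NC(=O)c3c(Cl)cccc3Cl)c2)ccc1O` gives 0.46 ug/mL 
- compound 2 `COc1cc(/C=C/C(=O)c2cccc(NC(=O)c3cccs3)c2)ccc1O` gives 0.38 ug/mL 

Compound 2 has only compound 1 to stand against, and the two cannot be told apart: the data show a 1.2-fold lower number from compound 1 to compound 2 (0.08 log units; within the scatter) and nothing more. The next compound, compound 3 `COc1cc(/C=C/C(=O)c2cccc(NC(=O)c3cc(Cl)cc(Cl)c3)c2)ccc1O`, carries 3,5-dichlorophenyl in place of thiophen-2-yl on a carbonyl carbon, a change counted as 3,5-dichlorophenyl in place of thiophen-2-yl on a carbonyl carbon in full.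

Going by the values given here, only one measured step bears on this change. That step joins thiophen-2-yl to a dichlorophenyl group at the same place, with 2,6-dichlorophenyl in compound 1, and it amounts to a 1.2-fold lower number from compound 1 to compound 2 (0.08 log units; within the scatter) in size. Among the compounds with values here, no measured compound carries 3,5-dichlorophenyl, so this evidence is a single pair and a different chlorine pattern. No shift beyond the scatter is therefore expected in this assay for this change. The expected step is a 1.1-fold higher number from compound 2 to compound 3 (0.04 log units; within the scatter) on this estimate. Compound 3 is estimated at 0.42 ug/mL with an expected range from 0.18 ug/mL to 1 ug/mL when measured.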

Compound 3, half-maximal inhibitory concentration: 0.75 ug/mL
The estimate for compound 3 lay 1.8-fold (0.25 log units) below the measured number; the measured number falls inside the stated range.
By their numbers in this assay, from the lowest: compounds 2, 1 and 3 (each within the scatter of the next).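

In this assay, the place on the carbonyl carbon whose other neighbour is the amide-type nitrogen has now held three different aromatic groups, and every step among them lies within the scatter: there is a 2.0-fold higher number from compound 2 to compound 3 (0.30 log units; within the scatter), and a 1.6-fold higher number from compound 1 to compound 3 (0.21 log units; within the scatter). The second of these steps adds something the first pair could not show, as 2,6-dichlorophenyl and 3,5-dichlorophenyl differ only in where the two chlorines stand, and this difference in chlorine pattern gives no readable change among these compounds. Nothing in the data shown offers an explanation for these numbers.

All three groups shown at this place are aromatic rings, so it remains open whether an aliphatic amine, a carboxylic acid or a longer alkyl chain on the same carbonyl carbon would give a step beyond the scatter. Also open, from the compounds shown here alone, is how the numbers respond to changes elsewhere on the shared core, as these three compounds differ at this one place only.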